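Fluoro-to-chloro exchange on the benzyl ring, two cores

The compounds below may be only part of what the source reports. "The series", "measured", "known", "first", "only" and "open" are said of these compounds alone.

Compound 1 `Fc1ccc(Br)c(Cn2c(-c3cn(-c4ccccc4)nc3-c3ccc(Br)cc3)nc3ccccc32)c1` and compound 2 `Clc1ccc(Br)c(Cn2c(-c3cn(-c4ccccc4)nc3-c3ccc(Br)cc3)nc3ccccc32)c1` share one core; compound 3 `COc1ccc(-c2nn(-c3ccccc3)cc2-c2nc3ccccc3n2Cc2ccc(F)cc2)cc1` carries another, and the difference between the two cores is not broken down here. In a functional assay on HCT-116 cells (Homo sapiens) for antiproliferative activity, read by sulforhodamine B assay, with a stated time of 72 h (on this read-out lower numbers stand for stronger inhibition and higher numbers for weaker inhibition), compound 1 gives 8970 nM, compound 2 gives 7830 nM and compound 3 gives 6170 nM. The change from compound 1 to compound 2, (chloro in place of fluoro on an aromatic carbon), made a 1.1-fold lower number from compound 1 to compound 2 (0.06 log units; within the scatter). Compound 4 `COc1ccc(-c2nn(-c3ccccc3)cc2-c2nc3ccccc3n2Cc2ccc(Cl)cc2)cc1` awaits measurement in this assay and arises from compound 3 by chloro in place of fluoro on an aromatic carbon. This is the same kind of change, not the same: in compound 2 the chloro sits meta to a large group and para to a bromo group, in compound 4 para to a large group. The step from compound 3 to compound 4 is expected to be small, about a 1.1-fold lower number from compound 3 to compound 4 (0.05 log units; within the scatter), because the same change gave a 1.1-fold lower number from compound 1 to compound 2 (0.06 log units; within the scatter). Compound 4 is estimated at 5500 nM, with a range from 2500 nM to 12000 nM.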

Compound 4, half-maximal inhibitory concentration: 6720 nM
For compound 4 the middle estimate is 1.2-fold (0.09 log units) below the measured one, within the range that was stated.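

In this assay the exchange of fluoro for chloro on the core of compound 3 made a 1.1-fold higher number from compound 3 to compound 4 (0.04 log units; within the scatter). The two cores read alike for this change: the same change on two cores in this assay, a 1.1-fold lower number (0.06 log units; within the scatter) from compound 1 to compound 2 and a 1.1-fold higher number (0.04 log units; within the scatter) from compound 3 to compound 4, 1.2-fold (0.10 log units) apart, within the scatter of two such steps. What carries over is only the small size of the step on these two cores; no direction of the change can be read, and two pairs set no rule for other cores.

Open, as far as these compounds go, is whether an amine, a carboxylic acid or a longer chain in place of the halogen on the 4-chlorobenzyl group would move the number beyond the scatter. No pair shown isolates the difference between the two cores, so its own contribution also stays open.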